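A few compounds are considered here, and "the series" means these few. Any claim that something is new, unique, unknown or untested is made for them only; others in the source may bear on it.

Within the data shown here, compound 1, with the structure `CC(C)[C@@H](NC(=O)c1cc2ccccc2s1)C(=O)N1CCC(c2ccc(Cl)cc2)CC1`, is one of two compounds measured in an assay on THP-1 cells for displacement of a labelled ligand from C-C chemokine receptor type 1 (Homo sapiens); a lower number here means a stronger inhibitor, a higher number a weaker inhibitor. In this assay compound 1 gives 58 nM, the lower of the two numbers. The other compound, compound 2, has the structure `CC(C)C(=O)NC(C(=O)N1CCC(c2ccc(Cl)cc2)CC1)C(C)C` and in this assay compound 2 gives 388 nM, a higher number whose gap to compound 1 lies beyond the usual scatter. Among the measured compounds shown here, the two differ in several places at once, so the two values show only that compound 1 is the stronger inhibitor of the pair.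

Compound 3, with the structure `CC(C)[C@@H](NC(=O)c1nc2ccccc2s1)C(=O)N1CCC(c2ccc(Cl)cc2)CC1`, has not yet been measured. It differs from compound 1 in one place: 1,3-benzothiazol-2-yl in place of 1-benzothiophen-2-yl on a carbonyl carbon. The new group keeps the same size and shape and adds one hydrogen-bond acceptor on the five-membered ring. Nothing measured here says how such a swap moves the number, so the step from compound 1 to compound 3 is expected to be small, about a 1.4-fold higher number from compound 1 to compound 3 (0.14 log units; within the scatter), and may not exceed the scatter. In this assay compound 3 is therefore estimated at 80 nM, within a range from 25 nM to 250 nM.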

Compound 3, half-maximal inhibitory concentration: 18 nM
Compound 3: middle estimate off by 4.4-fold (0.65 log units), on the high side, and the stated range ends above it.
By their numbers in this assay, from the lowest: compound 3; then compound 1; then compound 2.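

At this carbonyl carbon, whose other neighbour is an amide-type nitrogen, the choice of group matters in this assay: 1,3-benzothiazol-2-yl in place of 1-benzothiophen-2-yl gives a 3.2-fold lower number from compound 1 to compound 3 (0.51 log units; beyond the scatter) and so moves the number by more than repeat measurements would. The two groups hold the same count of heavy atoms and differ in that one carbon gives way to a nitrogen, so even an exchange of this size can shift the result. Nothing here accounts for why the number falls.

Going by these compounds, this is a single pair, so it remains open whether the same swap would give a similar step with a fluorine in place of the chlorine elsewhere in the molecule. On these data alone, it also remains open how other groups on this carbonyl carbon, such as 1,3-benzoxazol-2-yl or plain phenyl, would compare.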